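The source may report more compounds than this note shows. Statements on the series, on what has been measured and on what is new or still open speak of the compounds shown alone.

compound 1 `COc1ccc(Cl)cc1S(=O)(=O)Nc1ccc(-c2nc3ccccc3o2)cc1`: > 63000 nM
compound 2 `Cc1cccc(S(=O)(=O)Nc2ccc(-c3nc4ccccc4o3)cc2)c1`: > 63000 nM
compound 3 `O=S(=O)(Nc1ccc2oc(-c3ccccc3)nc2c1)c1cccc(O)c1`: > 63000 nM

In an assay on isolated protein for inhibition of malate dehydrogenase, mitochondrial (Sus scrofa), with stated times of 45 min and 30 min (a higher number here means a weaker inhibitor, a lower number a stronger inhibitor), compound 1 gives > 63000 nM, a limit of the assay and not a number. Compound 2 gives > 63000 nM there, likewise only a limit. Compound 3 stands at > 63000 nM in this assay, again a limit. Every value shown sits at this same limit (the limit of > 63000 nM in this assay, at which 3 of the 3 values shown sit). Among the compounds with values here, the one step between measured compounds that differ in a single place, a step that the two limits leave unreadable from compound 1 to compound 2, cannot be read in size from the two limits.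

Compound 4 `COc1ccc(Cl)cc1S(=O)(=O)Nc1ccc2oc(-c3ccccc3)nc2c1` is yet to be measured in this assay. It differs from compound 3 as 5-chloro-2-methoxyphenyl in place of 3-hydroxyphenyl on a sulfonyl sulfur. The same sulfonyl group that compound 1 carries thus enters on the core of compound 3. Within the data shown here, compound 1 sits at the limit, compound 3 sits at the limit, and the step from compound 1 to compound 2 has no readable size, so no measured step bears on this change with a size that could be used. No shift beyond the scatter can be derived, and the most likely outcome is once more a limit. The expected step that the limit leaves unreadable from compound 3 to compound 4 is therefore essentially none. Compound 4 is estimated at 100000 nM with a range from 40000 nM to 300000 nM in this assay.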

Compound 4, half-maximal inhibitory concentration: > 63000 nM
Compound 4: only a limit was reported (the forecaster's own chance of this, stated with the estimate: 85%); the middle value is on the limit's open side.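

No step can be read between compound 3 and compound 4, as each gives only a limit in this assay, and the series as a whole rests on one value: the limit of > 63000 nM in this assay, at which 4 of the 4 values shown sit. The compounds shown leave open which change, if any, would bring a readable number in this assay.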